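The compounds below may be only part of what the source reports. "The series", "measured", "known", "first", "only" and "open" are said of these compounds alone.

Measured compounds:
- compound 1, `COc1ccc(-c2nc(S(=O)(=O)c3cccc(Cl)c3)nc3ccsc23)cn1`: > 50000 nM
- compound 2, `COc1ccc(-c2nc(C(F)(F)S(=O)(=O)c3cccc(Cl)c3)nc3ccsc23)cn1`: > 50000 nM
- compound 3, `COc1ccc(-c2nc(CCc3cccc(Cl)c3)nc3ccsc23)cn1`: > 50000 nM

The three compounds share a core and were tested in an ADME assay on cells (Homo sapiens) for cytotoxicity, read by resazurin assay, with a stated time of 5 days; on this read-out lower numbers stand for higher toxicity in this test and higher numbers for lower toxicity in this test. For compound 1 the reported result is a limit of the assay rather than a number. For compound 2 the result is likewise a limit. Among the compounds with values here, for compound 3 the result is again a limit, so no numerical position can be given for it; all that is known is the limit of > 50000 nM in this assay, at which 3 of the 3 values shown sit, and no compound among the three separates itself from the others on this read-out.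

Compound 4, `COc1ccc(-c2nc(CSc3cccc(Br)c3)nc3ccsc23)cn1`, has not been measured. It differs from compound 3 in one place: (3-bromophenyl)sulfanyl in place of 3-chlorobenzyl on a saturated chain carbon bound to an aromatic carbon. Within the data shown here, no measured pair in this set shows what such a change does in this assay, so nothing here points to a step in either direction. The expectation is that compound 4 will also sit at the limit, with a step from compound 3 to compound 4 of a step that the limit leaves unreadable from compound 3 to compound 4 expected to lie within the scatter. Compound 4 is therefore estimated at 60000 nM in this assay, with a range from 30000 nM to 150000 nM.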

Compound 4, half-maximal cytotoxic concentration: > 50000 nM
Compound 4 ended at the assay's limit; the forecaster's own chance of this, stated with the estimate: 85%; the middle value is on the limit's open side.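

Compound 3 and compound 4 both gave a limit rather than a number in this assay, so no step between them can be read: the limit of > 50000 nM in this assay, at which 4 of the 4 values shown sit.

The compounds shown leave open where any of them would fall on a numerical scale in this assay, and what putting (3-bromophenyl)sulfanyl in place of 3-chlorobenzyl does there.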